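A few compounds are considered here, and "the series" means these few. Any claim that something is new, unique, unknown or untested is made for them only; others in the source may bear on it.

Measured compounds in a functional assay on G-361 cells (Homo sapiens) for antiproliferative activity, with a stated time of 72 h; on this read-out higher numbers stand for weaker inhibition and lower numbers for stronger inhibition:

Compound 1, `COc1ccccc1CNc1ncnc2c1ncn2[C@@H]1O[C@H](CO)[C@@H](O)[C@H]1O`: for compound 1 the result is a limit, > 166000 nM.
Compound 2, `COc1cc(CNc2ncnc3c2ncn3[C@@H]2O[C@H](CO)[C@@H](O)[C@H]2O)cc(OC)c1`: for compound 2 the entry in this assay is "not determined" (no result reported), with no result reported.
Compound 3, `OC[C@H]1O[C@@H](n2cnc3c(NCc4cc(F)cc(F)c4)ncnc32)C(O)C1O`: for compound 3 the result is again a limit, > 166000 nM.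

Compound 1 therefore stands nowhere on a scale of numbers: its entry in this assay is only a limit, and of the three entries shown two are limits and one is empty. Compound 3 sits at the same limit, as the limit of > 166000 nM in this assay, at which 2 of the 3 values shown sit, records. Between these measured compounds no step of a single change exists that could be read as a number.

The step under consideration leads from compound 1 to compound 4, `OC[C@H]1O[C@@H](n2cnc3c(NCc4ccc(F)cc4Cl)ncnc32)[C@H](O)[C@@H]1O`, with the change (2-chloro-4-fluorophenyl in place of 2-methoxyphenyl on a saturated chain carbon bound to a nitrogen on an aromatic ring). Going by the values given here, nothing among the measured values gives a direction for this change. With both determined entries at the limit, the expectation is that compound 4 shows no step beyond the scatter in this assay, and that the result will most likely again be reported as a limit rather than a number. Compound 4 is thus estimated at 200000 nM in this assay, between 40000 nM and 600000 nM. This estimate means a step that the limit leaves unreadable from compound 1 to compound 4, which is expected to remain within the scatter.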

Compound 4, half-maximal inhibitory concentration: > 166000 nM
Compound 4: no number, only a limit; the forecaster's own chance of this, stated with the estimate: 75%; the middle value is on the limit's open side.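

In this assay compound 4 gives > 166000 nM as a limit and not a number. Going by these compounds alone, compound 1 is recorded only as a limit too, so no step from compound 1 to compound 4 can be read, and the values gather at one limit: the limit of > 166000 nM in this assay, at which 3 of the 4 values shown sit. The compounds shown leave open whether any of them would give a number in this assay at all.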